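The compounds below may be only part of what the source reports. "The series", "measured", "known", "first", "only" and "open" are said of these compounds alone.

Measured compounds:
compound 1 `O=C(NO)c1ccc(CN2C(=O)NC(Cc3ccc4ccccc4c3)(c3ccccc3)C2=O)cc1` gives 74.6 nM
compound 2 `O=C(NO)c1ccc(CN2C(=O)C(Cc3ccccc3)N(Cc3ccccn3)C2=O)cc1` gives 4.8 nM

Both numbers come from an assay on isolated protein for inhibition of protein deacetylase HDAC6 (Homo sapiens), read by fluorescence, with stated times of 10 min and 2 h; on this read-out higher numbers stand for weaker inhibition and lower numbers for stronger inhibition. Of the two values, compound 2 gives the lower one and therefore stands at the lowest point of this small set; compound 1 gives the higher number, and the gap between the two lies beyond the usual scatter. Among the compounds with values here, no step between compounds that differ in only one place is available, so the pair says only this much.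

Compound 3 `O=C(NO)c1ccc(CN2C(=O)C(Cc3ccccc3)N(Cc3cccnc3)C2=O)cc1` has not yet been measured in this assay. It differs from compound 2 by pyridin-3-yl in place of pyridin-2-yl on a saturated chain carbon bound to an amide-type nitrogen in a ring: the same atoms joined differently, the nitrogen of the six-membered aromatic ring simply sitting at another position of that ring. Within the data shown here, no measured pair shows what such a shift of the ring nitrogen does here, so there is no basis for expecting a large move in either direction.

For compound 3 a step of a 1.3-fold higher number from compound 2 to compound 3 (0.10 log units; within the scatter) is expected, that is, a number close to that of compound 2 and not beyond the scatter. The estimate for compound 3 is 6 nM, with a range from 2.5 nM to 15 nM.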

Compound 3, half-maximal inhibitory concentration: 2.1 nM
The estimate for compound 3 lay 2.9-fold (0.46 log units) above the measured number; the whole stated range lies above it.
By their numbers in this assay, from the lowest: compound 3; then compound 2; then compound 1.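

In this assay, the place on a saturated chain carbon bound to an amide-type nitrogen in a ring responds to the position of the ring nitrogen alone: pyridin-3-yl in place of pyridin-2-yl gives a 2.3-fold lower number from compound 2 to compound 3 (0.36 log units; beyond the scatter) as a modest but real change in the series. Compound 2 and compound 3 contain the same atoms and have the same counts of hydrogen-bond donors and acceptors in the exchanged group, so this step shows that those counts alone do not fix the number at this place, which the earlier pair, differing in more than one place, could not show. Nothing available bears on what lies behind this step.

Still open, on these data alone, is how pyridin-4-yl, a plain phenyl ring or an amine-bearing chain would read at the same place, and whether the ring nitrogen is needed at all. Also open, as far as these compounds go, is whether the advantage of pyridin-3-yl over pyridin-2-yl carries over to other cores, such as that of compound 1, which differs from compound 2 and compound 3 in more than one place and so gives no reading on this change.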